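The source may hold more compounds than are shown below. What is called first, only, known or untested is meant among the compounds shown, and "the series" means these compounds.

Compound 1, `O=C(CN[C@H]1CCN(S(=O)(=O)Cc2ccccc2)C1)N1CCN(Cc2ccc(Cl)cc2)CC1`, stands lowest of the three numbers in hand for a functional assay on K562 cells (Homo sapiens) for cytotoxicity, read by MTT assay, with a stated time of 48 h; a lower number here means a stronger inhibitor, a higher number a weaker inhibitor: compound 1 gives 9200 nM. Compound 2, `O=C(CN[C@H]1CCN(S(=O)(=O)Cc2ccccc2)C1)N1CCN(Cc2ccccc2F)CC1`, gives 12600 nM, and the step of a 1.4-fold higher number from compound 1 to compound 2 (0.14 log units; within the scatter) lies within the scatter, so the two are not separated. Compound 3, `O=C(CN[C@H]1CCN(S(=O)(=O)Cc2ccccc2)C1)N1CCN(Cc2c(F)cccc2Cl)CC1`, gives 65800 nM; the step of a 7.2-fold higher number from compound 1 to compound 3 (0.85 log units; beyond the scatter) is beyond the scatter, as is a 5.2-fold higher number from compound 2 to compound 3 (0.72 log units; beyond the scatter).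

Compound 4, `COc1ccc(CN2CCN(C(=O)CN[C@H]3CCN(S(=O)(=O)Cc4ccccc4)C3)CC2)cc1`, differs from compound 1 in one place: methoxy in place of chloro on an aromatic carbon. The change sits on an aromatic carbon of a six-membered aromatic ring of carbon only, para to a large group. Going by the values given here, no measured step replaces one group by another at that carbon. Among the compounds with values here, the steps that bear on it do so only loosely: a 1.4-fold higher number from compound 1 to compound 2 (0.14 log units; within the scatter), where 2-fluorophenyl took the place of 4-chlorophenyl and nothing moved beyond the scatter, and a 7.2-fold higher number from compound 1 to compound 3 (0.85 log units; beyond the scatter), where 2-chloro-6-fluorophenyl took the place of 4-chlorophenyl and the number rose modestly. Neither tests methoxy. The step of a 1.3-fold higher number from compound 1 to compound 4 (0.12 log units; within the scatter) is therefore expected to be small, within the scatter or a little above it toward a higher number. Compound 4 is estimated at 12000 nM, with a range of 5000 nM to 30000 nM.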

Compound 4, half-maximal inhibitory concentration: 50900 nM
Estimate against measurement, compound 4: 4.2-fold (0.63 log units) below; the measured number lies above the stated range.
By their numbers in this assay, from the lowest: compounds 1 and 2 (each within the scatter of the next); then compounds 4 and 3 (each within the scatter of the next).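

At this aromatic carbon, para to a large group, chloro and methoxy are not interchangeable in this assay: the direct replacement gives a 5.5-fold higher number from compound 1 to compound 4 (0.74 log units; beyond the scatter), the only group-for-group change at that carbon among the compounds shown. The 4-methoxyphenyl of compound 4 also stands apart from the 2-fluorophenyl of compound 2, with a 4.0-fold higher number from compound 2 to compound 4 (0.61 log units; beyond the scatter), yet it is not separated from the 2-chloro-6-fluorophenyl of compound 3, with a 1.3-fold lower number from compound 3 to compound 4 (0.11 log units; within the scatter), so two differently substituted rings reach the same level. No measurement at hand accounts for the step from chloro to methoxy.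

Still open, from the compounds shown here alone, is how an amine, a carboxylic acid or a longer chain such as ethoxy at that carbon would compare with chloro and methoxy. Also open, going by these compounds, is how the unsubstituted phenyl would compare with 4-chlorophenyl and 4-methoxyphenyl on the same core.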